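Working notes on cell tolerance in a four-compound set

The compounds below may be only part of what the source reports. "The series", "measured", "known", "first", "only" and "open" are said of these compounds alone.

Measured compounds, with their values in an ADME assay on Vero cells (Chlorocebus sabaeus) for cytotoxicity, read by fluorescence and resazurin assay, with a stated time of 3 days; a higher number here means that more compound is tolerated, a lower number that less compound is tolerated:
compound 1, `COc1ccc(N/N=C2\C(=O)N(Cc3cn(O[C@@H]4O[C@H](CC(C)=O)[C@@H](OC(C)=O)[C@H](OC(C)=O)[C@H]4OC(C)=O)nn3)c3ccccc32)cc1`, gives 95300 nM
compound 2, `CC(=O)C[C@H]1O[C@@H](On2cc(CN3C(=O)/C(=N\Nc4ccc(C#N)cc4)c4ccccc43)nn2)[C@H](OC(C)=O)[C@@H](OC(C)=O)[C@@H]1OC(C)=O`, gives 75400 nM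
compound 3, `COc1ccc(N/N=C2\C(=O)N(Cc3cn(C[C@H]4O[C@@H]5OC(C)(C)O[C@@H]5[C@H]4O)nn3)c3ccccc32)cc1`, gives 74500 nM

Going by the values given here, the only paired change so far is cyano in place of methoxy on an aromatic carbon; in this assay it made a 1.3-fold lower number from compound 1 to compound 2 (0.10 log units; within the scatter). Compound 3 carries a different core from compound 1; how the two cores differ is not broken down here, and all three measured values sit within the scatter of one another.

Compound 4, `CC1(C)O[C@H]2O[C@H](Cn3cc(CN4C(=O)/C(=N\Nc5ccc(C#N)cc5)c5ccccc54)nn3)[C@H](O)[C@H]2O1`, is not yet measured. It differs from compound 3 by cyano in place of methoxy on an aromatic carbon, the same change as that from compound 1 to compound 2, at the same place. Since that change made a 1.3-fold lower number from compound 1 to compound 2 (0.10 log units; within the scatter), the step from compound 3 to compound 4 is expected to be of the same small size, a 1.2-fold lower number from compound 3 to compound 4 (0.09 log units; within the scatter), starting from the value of compound 3, 74500 nM. Compound 4 is therefore estimated at 60000 nM, expected to fall between 35000 nM and 110000 nM.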

Compound 4, half-maximal cytotoxic concentration: 105000 nM
Compound 4: middle estimate off by 1.8-fold (0.24 log units), on the low side; low and high end bracket the measured number.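

In this assay, cyano in place of methoxy on an aromatic carbon gives a 1.4-fold higher number from compound 3 to compound 4 (0.15 log units; within the scatter). Set beside the earlier step on the other core, the two steps cannot be told apart: the same change on two cores in this assay, a 1.3-fold lower number (0.10 log units; within the scatter) from compound 1 to compound 2 and a 1.4-fold higher number (0.15 log units; within the scatter) from compound 3 to compound 4, 1.8-fold (0.25 log units) apart, within the scatter of two such steps. This shows that, in these two pairs, the change moved from one core to the other with no step beyond the scatter, but it fixes neither a direction nor a size for the change and says nothing about any further core.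

The compounds shown leave open how this assay reads with anything other than methoxy or cyano at this place, such as an amine, a carboxylic acid or a longer chain. They also leave open whether any such group would give a step beyond the scatter on either core.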